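A few compounds are considered here, and "the series" means these few. Any claim that something is new, unique, unknown or untested is made for them only; others in the source may bear on it.

Compound 1 `Cc1ccccc1CN1CCN(C(=O)CN[C@H]2CCN(S(=O)(=O)Cc3ccccc3)C2)CC1`: 10200 nM
Compound 2 `O=C(CN[C@H]1CCN(S(=O)(=O)Cc2ccccc2)C1)N1CCN(Cc2cccc(Cl)c2)CC1`: 8600 nM

Among the measured compounds shown here, in a functional assay on K562 cells (Homo sapiens) for cytotoxicity, read by MTT assay, with a stated time of 48 h (a higher number here means a weaker inhibitor, a lower number a stronger inhibitor), compound 2, at 8600 nM, cannot be told apart from the only other measured compound. Compound 3 `O=C(CN[C@H]1CCN(S(=O)(=O)Cc2ccccc2)C1)N1CCN(Cc2ccc(F)cc2)CC1` changes one group at the same place: 4-fluorophenyl in place of 3-chlorophenyl on a saturated chain carbon bound to an amine nitrogen in a ring. For the measured compounds named here, the one measured step bearing on this is a 1.2-fold lower number from compound 1 to compound 2 (0.07 log units; within the scatter), which also swapped the substituted phenyl on that carbon. Going by the values given here, it is a single step, and no fluorinated compound has been measured yet, so the evidence is thin. The expected change, none beyond the scatter, is a 1.0-fold higher number from compound 2 to compound 3 (0.02 log units; within the scatter). For compound 3 the estimated value is 9000 nM, with an expected range of 4000 nM to 20000 nM.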

Compound 3, half-maximal inhibitory concentration: 14300 nM
Beside the measured number, compound 3's estimate is 1.6-fold (0.20 log units) below it, within the range that was stated.
By their numbers in this assay, from the lowest: compounds 2, 1 and 3 (each within the scatter of the next).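

In this assay the 4-fluorophenyl group gives a 1.7-fold higher number from compound 2 to compound 3 (0.22 log units; within the scatter) and a 1.4-fold higher number from compound 1 to compound 3 (0.15 log units; within the scatter) at this place. Fluorine on the phenyl ring therefore joins methyl and chlorine, and all three compounds stand within the scatter of one another, so none of these three substituted phenyl groups can be ranked above another. No measurement at hand offers a reason for these numbers. On these data alone, what a carboxylic acid or an amine on that phenyl ring would do stays open, as does the effect of a longer chain. Whether any group at this place can move the number beyond the scatter is also unknown.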